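Halogen swap on the benzyl sulfonamide of a catechol vinyl series

A few compounds are considered here, and "the series" means these few. Any claim that something is new, unique, unknown or untested is made for them only; others in the source may bear on it.

The three measured compounds share one core. Compound 1 `O=S(=O)(/C=C/c1ccc(O)c(O)c1)NCCCc1ccccc1` and compound 2 `O=S(=O)(/C=C/c1ccc(O)c(O)c1)NCCCCc1ccccc1` carry a saturated chain ending in a phenyl ring, while compound 3 `O=S(=O)(/C=C/c1ccc(O)c(O)c1)NCc1ccc(Cl)cc1` carries a 4-chlorobenzyl group on the sulfonamide nitrogen. In a functional assay on BV-2 cells (Mus musculus) for inhibition, read by Griess assay, with stated times of 3 h and 24 h (a higher number here means a weaker inhibitor, a lower number a stronger inhibitor), compound 1 gives 17500 nM, compound 2 gives 23800 nM, and compound 3 gives 13700 nM. Going by the values given here, the one single-point step among them, a 1.4-fold higher number from compound 1 to compound 2 (0.13 log units; within the scatter), is small. Compound 3 has the lowest of the three numbers, yet its gaps to compound 1 and to compound 2 both lie within the scatter, so no ranking can be drawn from these values.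

Compound 4 `O=S(=O)(/C=C/c1ccc(O)c(O)c1)NCc1ccc(F)cc1` is not yet measured. It differs from compound 3 by fluoro in place of chloro on an aromatic carbon. Among the compounds with values here, no measured step concerns an exchange of one halogen for another; the only step in hand moves a phenyl ring one carbon further out, and it stayed within the scatter. With nothing to point either way, a change no larger than the scatter is expected, and compound 4 is estimated to give 15000 nM in this assay, with a range from 7000 nM to 35000 nM. This estimate amounts to an expected 1.1-fold higher number from compound 3 to compound 4 (0.04 log units; within the scatter).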

Compound 4, half-maximal inhibitory concentration: 18900 nM
Compound 4: the middle estimate sits 1.3-fold (0.10 log units) below what was measured; measured number inside the range.
By their numbers in this assay, from the lowest: compounds 3, 1, 4 and 2 (each within the scatter of the next).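

Going by these compounds alone, the exchange of chloro for fluoro, on an aromatic carbon para to a large group, is the first step that touches this ring substituent rather than the chain. In this assay it amounts to a 1.4-fold higher number from compound 3 to compound 4 (0.14 log units; within the scatter), so the two halogens cannot be told apart at this position, and the 4-chlorophenyl to 4-fluorophenyl change has no readable effect on the number. This adds a second step within the scatter to the chain step, a 1.4-fold higher number from compound 1 to compound 2 (0.13 log units; within the scatter), and no data here offer a reason for the result or tie either halogen to a measured property.

From the compounds shown here alone, it remains open whether any group at this position can move the number beyond the scatter: a methoxy, a trifluoromethyl, a nitrile, a carboxylic acid, or simply hydrogen in place of the halogen could each give a different answer. Going by these compounds, it is also open whether the same exchange of chloro for fluoro would stay within the scatter on a phenyl ring at the end of the longer chains of compound 1 and compound 2.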